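Working notes: methoxy addition and cell tolerance in the series

A few compounds are considered here, and "the series" means these few. Any claim that something is new, unique, unknown or untested is made for them only; others in the source may bear on it.

Measured in an ADME assay on HepG2 2.2.15 cells (Homo sapiens) for cytotoxicity, read by CCK-8 assay, with a stated time of 8 days; a higher number here means that more compound is tolerated, a lower number that less compound is tolerated:

compound 1, `Cc1cccc(-c2cc(NC(=O)c3ccccc3O)c[nH]c2=O)c1`: 98800 nM
compound 2, `COc1ccc(C(=O)Nc2c[nH]c(=O)c(-c3cccc(C)c3)c2)c(O)c1`: > 100000 nM
compound 3, `CCOc1ccc(-c2cc(NC(=O)c3ccccc3O)c[nH]c2=O)cc1`: 41000 nM

The value recorded for compound 2 is a limit of this assay and not a number: the limit of > 100000 nM in this assay, at which 1 of the 3 values shown sits.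

Compound 2 differs from compound 1 by methoxy in place of hydrogen on an aromatic carbon. The step it made is an at least 1.0-fold higher number from compound 1 to compound 2 (0.00 log units; that floor lies within the scatter); since the second value is a limit, only a floor is known for this step, and that floor sits within the scatter.

Compound 3 carries the lowest number of the two numbers in hand; its nearest neighbour is compound 1, whose number is higher by a gap that lies beyond the scatter. How the core of compound 3 differs from the core of compound 1 is not broken down here.

Compound 4, `CCOc1ccc(-c2cc(NC(=O)c3ccc(OC)cc3O)c[nH]c2=O)cc1`, has not yet been measured. It differs from compound 3 by methoxy in place of hydrogen on an aromatic carbon. The place reads the same, word for word, as for the change from compound 1 to compound 2, so this is taken as the same change.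

In this assay the step expected from compound 3 to compound 4 is a 1.5-fold higher number from compound 3 to compound 4 (0.17 log units; within the scatter), set beside an at least 1.0-fold higher number from compound 1 to compound 2 (0.00 log units; that floor lies within the scatter); this rests on that single measured instance, which gave only a floor within the scatter, so no strong shift in either direction is assumed. Compound 4 is thus estimated at about 60000 nM, expected to lie between 30000 nM and 120000 nM.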

Compound 4, half-maximal cytotoxic concentration: 69600 nM
The estimate for compound 4 lay 1.2-fold (0.06 log units) below the measured number, and the stated range covers the measured number.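

In this assay the methoxy change on the core of compound 3 gives a 1.7-fold higher number from compound 3 to compound 4 (0.23 log units; within the scatter), and set beside its first instance on the core of compound 1 it reads: the same change on two cores in this assay, an at least 1.0-fold higher number (0.00 log units; that floor lies within the scatter) from compound 1 to compound 2 and a 1.7-fold higher number (0.23 log units; within the scatter) from compound 3 to compound 4; the limit leaves it open whether they differ. The value of compound 2 is a limit of the assay and not a number: the limit of > 100000 nM in this assay, at which 1 of the 4 values shown sits. The change therefore gives no step beyond the scatter on the core of compound 3 and only a floor within the scatter on the core of compound 1, so the pair does not show that it carries over at the same size, and the step with 4-ethoxyphenyl in place of 3-methylphenyl, an at least 1.4-fold lower number from compound 2 to compound 4 (0.15 log units; that floor lies within the scatter), is likewise only a floor within the scatter.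

The compounds shown hold only methoxy at this place, on two cores, so it stays open whether another group there, such as an amine, a carboxylic acid or a longer chain like ethoxy, would move the number beyond the scatter. On these data alone, it also stays open how the change behaves on further cores, and how large the step from compound 1 to compound 2 really is.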